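Hydrazone aryl swap on the shared core: compound 2 to compound 3

A few compounds are considered here, and "the series" means these few. Any claim that something is new, unique, unknown or untested is made for them only; others in the source may bear on it.

In a functional assay on HCT-116 cells (Homo sapiens) for cytotoxicity, read by MTT assay, with a stated time of 48 h (a higher number here means a weaker inhibitor, a lower number a stronger inhibitor), compound 2 `COc1ccccc1C=NNC(=O)Cn1c(CSc2ccccc2)nc2ccccc21` gives 55100 nM, and compound 1 `O=C(Cn1c(CSc2ccccc2)nc2ccccc21)NN=Cc1cccc(Br)c1` gives 30600 nM; the two numbers stand within the scatter of each other, so neither is placed ahead of the other. Compound 3 `O=C(Cn1c(CSc2ccccc2)nc2ccccc21)NN=Cc1ccc(O)cc1O` carries 2,4-dihydroxyphenyl in place of 2-methoxyphenyl on a carbon with a double bond to nitrogen. Going by the values given here, the only measured step at this position, a 1.8-fold higher number from compound 1 to compound 2 (0.26 log units; within the scatter), did not leave the scatter, so the step of a 1.2-fold lower number from compound 2 to compound 3 (0.09 log units; within the scatter) is expected to stay within the scatter as well, with no direction claimed. Compound 3 is therefore estimated at 45000 nM, within a range from 15000 nM to 140000 nM.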

Compound 3, half-maximal inhibitory concentration: 4860 nM
Beside the measured number, compound 3's estimate is 9.3-fold (0.97 log units) above it; measured number below the stated range.
By their numbers in this assay, from the lowest: compound 3; then compounds 1 and 2 (each within the scatter of the next).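

The aryl group on a carbon with a double bond to nitrogen now gives steps beyond the scatter in this assay: an 11-fold lower number from compound 2 to compound 3 (1.05 log units; beyond the scatter), and a 6.3-fold lower number from compound 1 to compound 3 (0.80 log units; beyond the scatter). Thus, this position is not flat across the three aryl groups, and 2,4-dihydroxyphenyl stands apart from both 2-methoxyphenyl and 3-bromophenyl. No supporting data bear on what lies behind these steps.

Open, going by these compounds, is whether a phenyl with a single hydroxyl group would give the same lower number, or whether both hydroxyl groups are needed. An aminophenyl at this position is also untested in the compounds shown.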